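From phenyl to 4-nitrophenyl: what size of step?

The source may hold more compounds than are shown below. What is called first, only, known or untested is meant among the compounds shown, and "the series" means these compounds.

Compound 1 `C=C(C)CC1COC2(C=CC(=O)C=C2)N(c2ccccc2)C1=O`: 450 nM
Compound 2 `O=C1C=CC2(C=C1)OCC(Cc1ccccc1)C(=O)N2c1ccccc1`: 570 nM
Compound 3 `O=C1C=CC2(C=C1)OCC(Cc1ccc(C(F)(F)F)cc1)C(=O)N2c1ccccc1`: 1650 nM

In a functional assay on BV-2 cells (Mus musculus), read by Griess assay, with a stated time of 24 h (on this read-out higher numbers stand for weaker inhibition and lower numbers for stronger inhibition), compound 2 gives 570 nM. It belongs to the stronger pair of the three numbers: a 1.3-fold higher number from compound 1 to compound 2 (0.10 log units; within the scatter). Compound 4 `O=C1C=CC2(C=C1)OCC(Cc1ccc([N+](=O)[O-])cc1)C(=O)N2c1ccccc1` keeps the shared core and changes one place: nitro in place of hydrogen on an aromatic carbon. The closest measured change is a 2.9-fold higher number from compound 2 to compound 3 (0.46 log units; beyond the scatter), where trifluoromethyl replaces hydrogen on an aromatic carbon. That is a single example with a different group, so it is weak evidence. A modest step towards weaker inhibition is expected, of similar size: a 2.1-fold higher number from compound 2 to compound 4 (0.32 log units; beyond the scatter). Compound 4 is estimated at 1200 nM, with an expected range from 450 nM to 3000 nM.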

Compound 4, half-maximal inhibitory concentration: 430 nM
For compound 4 the middle estimate is 2.8-fold (0.45 log units) above the measured one, and the stated range ends above it.
By their numbers in this assay, from the lowest: compounds 4, 1 and 2 (each within the scatter of the next); then compound 3.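

In this assay a group on this aromatic carbon does not by itself weaken inhibition: nitro in place of hydrogen gives a 1.3-fold lower number from compound 2 to compound 4 (0.12 log units; within the scatter), and 4-nitrophenyl in place of 1-methylethenyl gives a 1.0-fold lower number from compound 1 to compound 4 (0.02 log units; within the scatter), both within the scatter. The identity of the group does matter, as nitro in place of trifluoromethyl gives a 3.8-fold lower number from compound 3 to compound 4 (0.58 log units; beyond the scatter). Nothing measured here explains this gap between the two groups.

Going by these compounds, whether an amine, a carboxylic acid or a fluorine atom here would match nitro or trifluoromethyl stays open. On these data alone, with one compound for each group, the same groups elsewhere on the ring also remain unknown.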